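Series notes: from compound 3 to compound 4

A few compounds are considered here, and "the series" means these few. Any claim that something is new, unique, unknown or untested is made for them only; others in the source may bear on it.

Values in a functional assay (plasma) for inhibition, with Homo sapiens as the target; on this read-out lower numbers stand for stronger inhibition and higher numbers for weaker inhibition:
- compound 1 `O=C(O)CCC/C=C\C[C@H]1/C(=N/OCc2ccc(C(F)(F)F)cc2)CC[C@@H]1NS(=O)(=O)c1ccc(Cl)cc1` gives 200 nM
- compound 2 `Cc1ccc(S(=O)(=O)N[C@H]2CC/C(=N\OCc3ccc(C(F)(F)F)cc3)[C@@H]2C/C=C\CCCC(=O)O)cc1` gives 180 nM
- compound 3 `O=C(O)CCC/C=C\C[C@H]1/C(=N/OCC2CCCCC2)CC[C@@H]1NS(=O)(=O)c1ccc(F)cc1` gives 1800 nM
- compound 4 `O=C(O)CCC/C=C\C[C@H]1/C(=N/OCc2ccc(C(F)(F)F)cc2)CC[C@@H]1NS(=O)(=O)c1ccc(F)cc1` is not yet measured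

Compound 3 gives 1800 nM as the highest of the three numbers, and its gaps to compound 1 and compound 2 lie beyond the scatter. The structural change is 4-(trifluoromethyl)phenyl in place of cyclohexyl on a saturated chain carbon bound to an oxygen and it sits on a saturated chain carbon bound to an oxygen. Among the compounds with values here, no measured step isolates this change. Compound 1 and compound 2 already carry the entering 4-(trifluoromethyl)phenyl, but they also differ from compound 3 on the aromatic carbon that bears chloro or methyl. Within the data shown here, the one measured step at that place, a 1.1-fold lower number from compound 1 to compound 2 (0.05 log units; within the scatter), stayed within the scatter. Fluoro at that place remains untested alongside the entering group, so compound 4 is only expected to fall near compound 1 and compound 2. In this assay the expected step is an 8.2-fold lower number from compound 3 to compound 4 (0.91 log units; beyond the scatter) toward a lower number and beyond the scatter. The estimated value for compound 4 is 220 nM with an expected range from 100 nM to 500 nM on this reasoning.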

Compound 4, half-maximal inhibitory concentration: 620 nM
For compound 4 the middle estimate is 2.8-fold (0.45 log units) below the measured one, outside the stated range (above it).
By their numbers in this assay, from the lowest: compounds 2 and 1 (each within the scatter of the next); then compound 4; then compound 3.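

In this assay, the change from cyclohexyl to 4-(trifluoromethyl)phenyl on a saturated chain carbon bound to an oxygen can now be read alone, with fluoro held fixed on the aromatic carbon, and it gives a modest step (a 2.9-fold lower number from compound 3 to compound 4 (0.46 log units; beyond the scatter)). The aromatic carbon also turns out to matter, although chloro and methyl there stayed within the scatter of each other: fluoro separates from both (a 3.1-fold higher number from compound 1 to compound 4 (0.49 log units; beyond the scatter); a 3.4-fold higher number from compound 2 to compound 4 (0.54 log units; beyond the scatter)). No supporting data bear on the reason for either step.

Cyclohexyl appears only with fluoro on the aromatic carbon, so whether the size of the first step holds with chloro or methyl there remains open. Also open, from the compounds shown here alone, is how a nitrile or a methoxy group on that aromatic carbon would compare with these three substituents.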